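Solubility From Compound 2 to Compound 4

This account rests on a few compounds, and the source may have more. Where it says the series, first, only, none or still open, it means among the compounds named here.

Measured so far:
compound 1 `C[C@@H]1CN(c2c(C#N)c(C(F)(F)F)nn2-c2ccc(S(C)(=O)=O)cc2)[C@H](C)CO1` — in a physicochemical assay for solubility (a higher number here means a more soluble compound, a lower number a less soluble compound), compound 1 gives "not determined" (no result reported)
compound 2 `C[C@@H]1CN(c2c(C#N)c(C(F)F)nn2-c2ccc(S(C)(=O)=O)cc2)[C@H](C)CO1` — 50 ug/mL
compound 3 `CS(=O)(=O)c1ccc(-n2nc(C(F)(F)F)c(C#N)c2NCC2CC2)cc1` — in this assay compound 3 gives "not determined" (no result reported)

Going by the values given here, compound 2 is the only one of the three with a number in this assay; compounds 1 and 3 report none, so no step between measured compounds can be drawn. Compound 4 `CS(=O)(=O)c1ccc(-n2nc(C(F)F)c(C#N)c2NC2CCCC2)cc1` differs from compound 2 in one place: a group of 6 heavy atoms (5 carbon, 1 nitrogen; one five-membered non-aromatic ring of carbon only) in place of a group of 8 heavy atoms (6 carbon, 1 nitrogen, 1 oxygen; one six-membered non-aromatic ring with 2 hetero atoms), on an aromatic carbon. Among the compounds with values here, nothing among the measured compounds shows what such a change does here. A modest fall in solubility, just beyond the usual scatter, is the expected step of a 2.5-fold lower number from compound 2 to compound 4 (0.40 log units; beyond the scatter). Compound 4 is therefore estimated at 20 ug/mL, in the range 7 ug/mL to 60 ug/mL, because compound 2 gives 50 ug/mL as the only anchor.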

Compound 4, solubility: 100 ug/mL
Compound 4: middle estimate off by 5.0-fold (0.70 log units), on the low side; measured number above the stated range.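

At this aromatic carbon, cyclopentylamino takes the place of the six-membered non-aromatic ring with 2 hetero atoms, and this assay gives a 2.0-fold higher number from compound 2 to compound 4 (0.30 log units; within the scatter). So this exchange, which removes the ring oxygen and the 2 defined stereocentres and brings in a hydrogen-bond donor, leaves the two compounds inseparable in this read-out. Nothing measured here bears on why that is so. As far as these compounds go, whether a piperidine ring or an open chain such as propylamino at this carbon would give a step beyond the scatter stays open. So does how the same exchange reads with trifluoromethyl on the shared core, as in compound 1.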